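This account rests on a few compounds, and the source may have more. Where it says the series, first, only, none or still open, it means among the compounds named here.

Working notes on the series. Compound 1 `CN(C)C(=O)C(=O)CCc1ccc(Cl)cc1` gives in an assay on HEK-293T cells for inhibition of phospholipase A and acyltransferase 4 (Homo sapiens), with stated times of 30 min and 20 min (on this read-out lower numbers stand for stronger inhibition and higher numbers for weaker inhibition), only a limit of the assay, > 10000 nM. Compound 2 `CN1CCN(C(=O)C(=O)CCc2ccc(Cl)cc2)CC1` likewise returns only a limit in this assay, > 10000 nM. Compound 1 thus stands at the limit of > 10000 nM in this assay, at which 2 of the 2 values shown sit, with no number to order it against compound 2. Compound 3 `O=C(CCc1ccc(Cl)cc1)C(=O)N1CCCC1` carries pyrrolidin-1-yl in place of dimethylamino on a carbonyl carbon. Within the data shown here, no measured step shows how such a change acts. With both known values sitting at the limit, no shift beyond the scatter is expected, and the expected step is a number no higher from compound 1 to compound 3 (the limit leaves the size open). Compound 3 is therefore expected to give 10000 nM, within 3000 nM to 30000 nM, most likely again reported as a limit.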

Compound 3, half-maximal inhibitory concentration: > 10000 nM
Compound 3 was reported as a limit; the forecaster's own chance of this, stated with the estimate: 75%; the middle value lies on the limit itself.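

In this assay compound 3 gives > 10000 nM, a limit of the assay and not a number. Compound 1 also gives only a limit, so no step can be read between compound 1 and compound 3. The compounds shown leave open how any change on the shared core acts on this read-out: the limit of > 10000 nM in this assay, at which 3 of the 3 values shown sit.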